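The source may hold more compounds than are shown below. What is called first, only, known or untested is meant among the compounds shown, and "the series" means these compounds.

Compound 1 `Cc1cc2nn(-c3ccccc3)c(C)c2c(=O)o1`: 55.1%
Compound 2 `Cc1cc2nn(-c3ccc(Cl)cc3)c(C)c2c(=O)o1`: 59.6%

In a functional assay on the whole organism for inhibition, with Rattus norvegicus as the target, read by paw edema, with a stated time of 2 h, at a dose of 50 mg/kg (a lower number here means less inhibition, a higher number more inhibition at the dose given (going by the name of the read-out)), compound 2 gives 59.6%, the higher of the two numbers, with compound 1 the nearest at 55.1%. Among the measured compounds shown here, the one measured step, a number 4.5 percentage points higher from compound 1 to compound 2 (within the scatter), lies within the scatter. Compound 3 `COc1ccc(-n2nc3cc(C)oc(=O)c3c2C)cc1` differs from compound 2 by methoxy in place of chloro on an aromatic carbon. For the measured compounds named here, no measured step shows methoxy in place of chloro here, and the only change at this position, from compound 1 to compound 2, was small. Compound 3 is therefore expected to stay close to compound 2, with a step of a number 3.6 percentage points lower from compound 2 to compound 3 (within the scatter). The estimate for compound 3 is 56%, in the range 42% to 70%.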

Compound 3, a percentage reported as inhibition, in the whole organism at one dose (the size of the read-out at that dose, not a potency): 53.9%
The estimate for compound 3 lay 2.1 percentage points above the measured number, within the range that was stated.
By their numbers in this assay, from the lowest: compounds 3, 1 and 2 (each within the scatter of the next).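

With methoxy on this aromatic carbon, the read-out in this assay gives a number 5.7 percentage points lower from compound 2 to compound 3 (within the scatter) and a number 1.2 percentage points lower from compound 1 to compound 3 (within the scatter) so hydrogen, chloro and methoxy at this place are not told apart. The hydrogen-bond acceptor that methoxy brings, and its extra heavy atom, go with no step beyond the scatter. No supporting data bear on why this is so. Going by these compounds, whether an amine, a carboxylic acid or a longer chain at this place would move the number beyond the scatter stays open.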